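Inverting one ring stereocentre of a pyrrolidinyl epoxide lactone

The source may hold more compounds than are shown below. What is called first, only, known or untested is meant among the compounds shown, and "the series" means these compounds.

Compound 1 `C/C1=C\CC[C@@]2(C)O[C@@H]2[C@H]2OC(=O)[C@@H](CN3CCCC3)[C@@H]2C[C@H]1O` is measured in a functional assay on Hs 683 cells (Homo sapiens) for inhibition, read by colorimetric assay and MTT assay, with a stated time of 72 h (a lower number here means a stronger inhibitor, a higher number a weaker inhibitor), where compound 1 gives 15000 nM. This is the highest of the three numbers seen so far: compound 2 `C/C1=C\CC[C@@]2(C)O[C@@H]2[C@H]2OC(=O)[C@@H](CN3CCCCC3)[C@@H]2C[C@H]1O` gives 7000 nM, a change of a 2.1-fold lower number from compound 1 to compound 2 (0.33 log units; beyond the scatter), and compound 3 `C/C1=C\CC[C@@]2(C)O[C@@H]2[C@H]2OC(=O)[C@@H](CN(C)CCN(C)C)[C@@H]2C[C@H]1O` gives 9000 nM, a change of a 1.7-fold lower number from compound 1 to compound 3 (0.22 log units; within the scatter). Compound 4 `C/C1=C\CC[C@@]2(C)O[C@@H]2[C@H]2OC(=O)[C@@H](CN3CCCC3)[C@@H]2C[C@@H]1O` differs from compound 1 as follows: the two compounds have the same atoms and bonds and differ only in configuration as drawn: 1 of 7 stereo elements differ; a stereocentre at a saturated ring carbon is drawn R in compound 1 and S in compound 4. Going by the values given here, none of the measured steps concerns such an inversion; all three swap the amine group, so they offer no guide to size or direction here. The step to compound 4 is therefore expected to be no change at the digits printed from compound 1 to compound 4 (within the scatter), and compound 4 is estimated to give 15000 nM, within a wide range from 4000 nM to 50000 nM.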

Compound 4, half-maximal inhibitory concentration: 10000 nM
Estimate against measurement, compound 4: 1.5-fold (0.18 log units) above, within the range that was stated.
By their numbers in this assay, from the lowest: compounds 2, 3, 4 and 1 (each within the scatter of the next, the first and the last beyond it).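

Going by these compounds alone, the earlier compounds changed only the amine group, so this is the first look at configuration at this saturated ring carbon. In this assay, inverting it gives a 1.5-fold lower number from compound 1 to compound 4 (0.18 log units; within the scatter), so with pyrrolidin-1-yl on the chain the two configurations cannot be told apart here. The comparison is a clean one, with nothing else in the pair to account for: the fact that compounds 1 and 4 differ only in the configuration as drawn

As far as these compounds go, whether the inversion reads the same with the piperidin-1-yl group of compound 2 remains open. So does its outcome with a morpholine on the chain, or at the other stereocentres of the shared core.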